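The compounds below may be only part of what the source reports. "The series", "measured", "known", "first", "only" and "open" are said of these compounds alone.

Measured in a functional assay on A549 cells (Homo sapiens) for inhibition, read by CCK-8 assay, with a stated time of 72 h, tested at 1 uM; on this read-out higher numbers stand for more inhibition of growth at the one concentration tested and lower numbers for less inhibition of growth:
- compound 1 `Cc1cccc(NC(=O)C2(C(=O)Nc3ccc(Nc4ncc5cc(C(=O)N(C)C)n(C6CCCC6)c5n4)cc3)CC2)c1`: 35.2%
- compound 2 `Cc1ccc(NC(=O)C2(C(=O)Nc3ccc(Nc4ncc5cc(C(=O)N(C)C)n(C6CCCC6)c5n4)cc3)CC2)cc1`: 40.2%

Compound 2, at 40.2%, stands level with compound 1 within the scatter, so neither can be ranked above the other. The next compound to be read is compound 3 `CN(C)C(=O)c1cc2cnc(Nc3ccc(NC(=O)C4(C(=O)Nc5cccc(C#N)c5)CC4)cc3)nc2n1C1CCCC1`, which has 3-cyanophenyl in place of 4-methylphenyl on an amide-type nitrogen.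

Going by the values given here, only one measured step bears on this place, a number 5 percentage points higher from compound 1 to compound 2 (within the scatter), with 4-methylphenyl in place of 3-methylphenyl on the same nitrogen. That step stayed within the scatter, but it involves no nitrile, so it offers only weak guidance and the range must stay wide. In this assay, the expected step is a number 4.2 percentage points lower from compound 2 to compound 3 (within the scatter), which means no change beyond the scatter is expected. For compound 3 the estimated value is 36%, with an expected range of 22% to 52%.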

Compound 3, percent growth inhibition at one concentration: 70.8%
The estimate for compound 3 lay 34.8 percentage points below the measured number, and the stated range ends below it.
By their numbers in this assay, from the lowest: compounds 1 and 2 (each within the scatter of the next); then compound 3.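

In this assay, the group on the amide-type nitrogen can move growth inhibition well beyond the scatter, which the exchange of 3-methylphenyl for 4-methylphenyl did not show. The change to 3-cyanophenyl gives a number 30.6 percentage points higher from compound 2 to compound 3 (beyond the scatter), and the closest comparison, cyano in place of methyl on an aromatic carbon, gives a number 35.6 percentage points higher from compound 1 to compound 3 (beyond the scatter), so the methyl-to-cyano exchange alone is enough for a large step. No available measurement accounts for this step.

From the compounds shown here alone, whether the step is specific to the nitrile remains open, since a carboxylic acid, a primary amide or an aminomethyl group on the same ring could read differently. Going by these compounds, how 4-cyanophenyl compares with 3-cyanophenyl also remains open, as does how compound 3 behaves at other concentrations.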